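Swapping the aryl group on a sulfonamide nitrogen

The source may hold more compounds than are shown below. What is called first, only, known or untested is meant among the compounds shown, and "the series" means these compounds.

Measured compounds:
compound 1 `CC(C)CN(c1ccc(F)cc1)S(=O)(=O)c1ccc2c(c1)C(O)CC(C1CCOCC1)O2`, 3.39
compound 2 `CC(C)CN(c1cccc(F)c1)S(=O)(=O)c1ccc2c(c1)C(O)CC(C1CCOCC1)O2`, 3.39
compound 3 `CC(C)CN(c1ccc(N(C)C)cc1)S(=O)(=O)c1ccc2c(c1)C(O)CC(C1CCOCC1)O2`, 3.51

In a physicochemical assay for lipophilicity, at pH 7.4 (on this read-out lower numbers stand for lower lipophilicity and higher numbers for higher lipophilicity), compound 3 gives the highest of the three numbers, though its gap to either neighbour is small, as a number 0.12 log units higher from compound 1 to compound 3 (within the scatter) and a number 0.12 log units higher from compound 2 to compound 3 (within the scatter) show. Compound 4 `CC(C)CN(c1ccc(F)cc1F)S(=O)(=O)c1ccc2c(c1)C(O)CC(C1CCOCC1)O2` has not been measured. The change is 2,4-difluorophenyl in place of 4-(dimethylamino)phenyl on a sulfonamide nitrogen. The step from compound 1 to compound 3 is the closest guide, since it undid a fluoro-to-dimethylamino swap, and no change at the digits printed from compound 1 to compound 2 (within the scatter) shows that moving a fluorine did nothing. Returning to a fluorinated ring with a second fluorine is therefore expected to leave this assay roughly where compound 3 sits, giving an estimated a number 0.01 log units lower from compound 3 to compound 4 (within the scatter). For compound 4 the expected value is 3.5, within 3.2 to 3.8.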

Compound 4, distribution coefficient: 3.53
Compound 4: middle estimate off by 0.03 log units, on the low side, within the range that was stated.
By their numbers in this assay, from the lowest: compounds 1, 2, 3 and 4 (each within the scatter of the next).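

Adding a second fluorine to the aryl ring on the sulfonamide nitrogen leaves the number in this assay within the scatter (a number 0.14 log units higher from compound 1 to compound 4 (within the scatter)). The 2,4-difluorophenyl group also cannot be told apart from the 3-fluorophenyl group (a number 0.14 log units higher from compound 2 to compound 4 (within the scatter)) or the 4-(dimethylamino)phenyl group (a number 0.02 log units higher from compound 3 to compound 4 (within the scatter)). At this position, all four aryl groups therefore read alike, and nothing available explains this sameness. Still open, on these data alone, is whether a carboxylic acid on the aryl ring, or a saturated amine in place of that ring, would also stay within the scatter in this assay.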